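The source may report more compounds than this note shows. Statements on the series, on what has been measured and on what is new or still open speak of the compounds shown alone.

Measured compounds:
compound 1, `O=C1Nc2ccccc2/C1=C1/Cc2ccccc2C1=O`: > 100000 nM
compound 2, `O=C1Nc2ccc(Br)cc2/C1=C1/Cc2ccccc2C1=O`: 41400 nM
compound 3, `O=C1NC(=S)N/C1=C1\C(=O)Nc2ccccc21`: 51900 nM

All three were tested in a functional assay on U-373MG ATCC cells (Homo sapiens) for antiproliferative activity, read by MTT assay, with a stated time of 72 h; on this read-out higher numbers stand for weaker inhibition and lower numbers for stronger inhibition. In this assay compound 1 gives > 100000 nM, which is a limit of the assay and not a number; this is the limit of > 100000 nM in this assay, at which 1 of the 3 values shown sits. Compound 2 gives 41400 nM, and the step of an at least 2.4-fold lower number from compound 1 to compound 2 (0.38 log units; beyond the scatter) comes from bromo in place of hydrogen on an aromatic carbon. Compound 3 gives 51900 nM; the difference between its core and the core of compound 1 is not broken down here, and its value and that of compound 2 lie within the scatter of each other.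

Compound 4, `O=C1NC(=S)N/C1=C1\C(=O)Nc2c(Br)cccc21`, has not yet been measured in this assay. It differs from compound 3 by bromo in place of hydrogen on an aromatic carbon, the same kind of change as from compound 1 to compound 2, though the place differs: ortho and meta to a fused ring here, meta and para there. Resting on the step of an at least 2.4-fold lower number from compound 1 to compound 2 (0.38 log units; beyond the scatter), a step of about a 2.1-fold lower number from compound 3 to compound 4 (0.32 log units; beyond the scatter) is expected, so compound 4 is estimated at 25000 nM, between 8000 nM and 80000 nM.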

Compound 4, half-maximal inhibitory concentration: 4700 nM
Compound 4: the middle estimate sits 5.3-fold (0.73 log units) above what was measured; the whole stated range lies above it.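

In this assay, bromo in place of hydrogen on an aromatic carbon gives an 11-fold lower number from compound 3 to compound 4 (1.04 log units; beyond the scatter), so on both cores shown the change lowers the number by more than the scatter. What this does not show is whether the size of the step carries over from one core to the other, and the bromo also sits at a different place on each core: the same change on two cores in this assay, an at least 2.4-fold lower number (0.38 log units; beyond the scatter) from compound 1 to compound 2 and an 11-fold lower number (1.04 log units; beyond the scatter) from compound 3 to compound 4; the limit leaves it open whether they differ. The value of compound 1 is a limit of the assay and not a number: the limit of > 100000 nM in this assay, at which 1 of the 4 values shown sits.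

The compounds shown leave open whether another group in the place of the bromo on the core of compound 4, such as chloro, methoxy or an amine, would give a step of similar size. They also leave open whether bromo would lower the number on a third core.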